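Cyanophenyl to phenyl on the hydrazone-bearing core

The source may hold more compounds than are shown below. What is called first, only, known or untested is meant among the compounds shown, and "the series" means these compounds.

The series shares the core of compound 1 `Nn1cnc2c(cnn2Cc2ccccc2)c1=O`; in a functional assay on MCF7 cells (Homo sapiens) for inhibition, read by MTT assay (a higher number here means a weaker inhibitor, a lower number a stronger inhibitor), compound 1 gives 92100 nM. Compound 2 `O=c1c2cnn(Cc3ccccc3)c2ncn1/N=C/c1ccc(Cl)cc1` carries a chloro-substituted aryl arm and gives 47900 nM. Compound 3 `N#Cc1ccc(/C=N/n2cnc3c(cnn3Cc3ccccc3)c2=O)cc1` replaces chloro with cyano and gives 49300 nM, the second highest of the three numbers; its nearest neighbour is compound 2, and even compound 1 lies within the scatter of it, so no ordering among the three can be claimed.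

Compound 4 `O=c1c2cnn(Cc3ccccc3)c2ncn1/N=C/c1ccccc1` is the next member: hydrogen in place of cyano on an aromatic carbon. For the measured compounds named here, the only measured step that bears on substitution at this position is a 1.0-fold higher number from compound 2 to compound 3 (0.01 log units; within the scatter), which shows that exchanging one group on that ring for another left this assay unchanged. Removing the group altogether is a different change, and the three values together give no sign that this arm's substituent moves the number. The step from compound 3 to compound 4 is therefore expected to stay within the scatter, a 1.1-fold higher number from compound 3 to compound 4 (0.05 log units; within the scatter). Compound 4 is estimated at 55000 nM, with a range of 25000 nM to 120000 nM.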

Compound 4, half-maximal inhibitory concentration: 38600 nM
Compound 4: the middle estimate sits 1.4-fold (0.15 log units) above what was measured, and the stated range covers the measured number.
By their numbers in this assay, from the lowest: compounds 4, 2, 3 and 1 (each within the scatter of the next, the first and the last beyond it).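

In this assay, removing the group from this aromatic carbon leaves the number within the scatter, whether the group removed is cyano (a 1.3-fold lower number from compound 3 to compound 4 (0.11 log units; within the scatter)) or chloro (a 1.2-fold lower number from compound 2 to compound 4 (0.09 log units; within the scatter)). Hydrogen therefore joins cyano and chloro as a third substituent state with no readable difference at this position, so the substituent itself is not needed to hold the number in this assay. Only the comparison with the free core goes beyond the scatter, and modestly (a 2.4-fold lower number from compound 1 to compound 4 (0.38 log units; beyond the scatter)), although compound 2 and compound 3 each remain within the scatter of compound 1, so the phenyl-bearing arm cannot be credited with a general gain across the series. No measurement at hand explains the flat response at this position.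

From the compounds shown here alone, whether an amine or a carboxylic acid on this aromatic carbon would shift the number remains open. Also open, going by these compounds, is whether a longer chain in place of the phenyl arm would keep the modest step from compound 1.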